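Amide series: replacing the pyrimidinyl on the ring nitrogen

The compounds below may be only part of what the source reports. "The series", "measured", "known", "first", "only" and "open" are said of these compounds alone.

Measured so far:
- compound 1 `Cc1nccc(N2CCc3nc(C4(C(=O)Nc5ccc(F)cc5)CCC4)ccc32)n1`: 430 nM
- compound 2 `COC(=O)N1c2ccc(C3(NC(=O)c4ccc(F)cc4)CC3)cc2[C@H]2CC[C@H]21`: 300 nM
- compound 3 `Cc1nccc(N2c3ccc(C4(NC(=O)c5ccc(F)cc5)CC4)cc3[C@H]3CC[C@H]32)n1`: 64 nM

In an assay on blood for inhibition of Indoleamine 2,3-dioxygenase 1 (Homo sapiens) (a higher number here means a weaker inhibitor, a lower number a stronger inhibitor), compound 1 gives the highest of the three numbers. Compound 2 sits nearest, within the scatter, while compound 3 lies beyond it. For the measured compounds named here, the only one-point step measured is a 4.7-fold lower number from compound 2 to compound 3 (0.67 log units; beyond the scatter), on a different core from that of compound 1, where a 2-methylpyrimidin-4-yl entered in place of a methoxycarbonyl.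

Compound 4 `O=C(c1cccc(Cl)c1)N1CCc2nc(C3(C(=O)Nc4ccc(F)cc4)CCC3)ccc21` is not yet measured. It differs from compound 1 by (3-chlorophenyl)carbonyl in place of 2-methylpyrimidin-4-yl on a nitrogen on an aromatic ring in a ring. This runs against the direction of the measured step: the 2-methylpyrimidin-4-yl, whose arrival lowered the number in a 4.7-fold lower number from compound 2 to compound 3 (0.67 log units; beyond the scatter), is now removed and a carbonyl-linked group enters in its place. That step is the only bearing one, and it was recorded on another core, so the transfer is uncertain. A modestly higher number is therefore expected for compound 4 in this assay, a 2.8-fold higher number from compound 1 to compound 4 (0.45 log units; beyond the scatter), estimated at 1200 nM with a range from 400 nM to 4000 nM.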

Compound 4, half-maximal inhibitory concentration: 93 nM
For compound 4 the middle estimate is 13-fold (1.11 log units) above the measured one; measured number below the stated range.
By their numbers in this assay, from the lowest: compounds 3 and 4 (each within the scatter of the next); then compounds 2 and 1 (each within the scatter of the next).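

The 2-methylpyrimidin-4-yl is not needed for a lower number in this assay on this core: (3-chlorophenyl)carbonyl on the same nitrogen gives one (a 4.6-fold lower number from compound 1 to compound 4 (0.66 log units; beyond the scatter)). The earlier step at such a nitrogen (a 4.7-fold lower number from compound 2 to compound 3 (0.67 log units; beyond the scatter)) also lowered the number, but there the methoxycarbonyl, also joined through a carbonyl, was the group that left, so a carbonyl-linked group is not in itself tied to a higher number, and the ranking of groups at this position does not carry from one core to the other. Nothing available explains the direction of either step.

Open, going by these compounds, is whether the carbonyl link or the chlorine carries the new step; an unsubstituted benzoyl or a sulfonyl-linked 3-chlorophenyl on the same nitrogen would separate the two. Also open, on these data alone, is how (3-chlorophenyl)carbonyl behaves on the core of compound 3.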